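The compounds below may be only part of what the source reports. "The series", "measured", "known", "first", "only" and "open" are said of these compounds alone.

In an assay for inhibition of Amine oxidase [flavin-containing] B (Bos taurus), read by fluorescence, with a stated time of 30 min (on this read-out higher numbers stand for weaker inhibition and lower numbers for stronger inhibition), three compounds have been measured so far:

Compound 1, `Cc1cc(=O)oc2cc(OCc3nnc(S)s3)ccc12`, gives 896 nM.
Compound 2, `Cc1c(C)c2ccc(OCc3nnc(S)s3)cc2oc1=O`, gives 572 nM.
Compound 3, `Cc1cc(=O)oc2cc(OCC(=O)NNC(=S)Nc3ccc(Cl)cc3)ccc12`, gives 620 nM.

Compound 1 and compound 2 differ in one place only: methyl in place of hydrogen on an aromatic carbon. This change made a 1.6-fold lower number from compound 1 to compound 2 (0.19 log units; within the scatter). Compound 3 differs from compound 1 in more than one place, so the difference between the two cores is not broken down here; the two values stand close together.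

Compound 4, `Cc1c(C)c2ccc(OCC(=O)NNC(=S)Nc3ccc(Cl)cc3)cc2oc1=O`, has not yet been measured in this assay. It arises from compound 3 by the same change that turned compound 1 into compound 2: methyl in place of hydrogen on an aromatic carbon. The surroundings of the changed carbon read the same in both cases, so the same change is in play. Among the measured compounds shown here, the only guide to its size is the earlier step, which stayed within the scatter, and a step of about that size is expected here as well, a 1.5-fold lower number from compound 3 to compound 4 (0.17 log units; within the scatter). That expectation rests on the step of a 1.6-fold lower number from compound 1 to compound 2 (0.19 log units; within the scatter) and on compound 3 giving 620 nM. Compound 4 is therefore expected to give about 420 nM, most likely between 200 nM and 900 nM.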

Compound 4, inhibition constant: 561 nM
Beside the measured number, compound 4's estimate is 1.3-fold (0.13 log units) below it, and the stated range covers the measured number.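

In this assay, methyl in place of hydrogen on an aromatic carbon gave a 1.1-fold lower number from compound 3 to compound 4 (0.04 log units; within the scatter). Set beside the earlier step on the other core, the change looks the same on both cores as far as these numbers can tell: the same change on two cores in this assay, a 1.6-fold lower number (0.19 log units; within the scatter) from compound 1 to compound 2 and a 1.1-fold lower number (0.04 log units; within the scatter) from compound 3 to compound 4, 1.4-fold (0.15 log units) apart, within the scatter of two such steps. This shows that the step carries over from one core to the other without any detectable difference, but both steps lie within the scatter, so it does not show that the methyl shifts the number at all, and two cores are too few to make a rule for the series.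

Going by these compounds, all four compounds carry only hydrogen or methyl on this carbon, so it remains open what an ethyl group, a longer chain or an amine would do there. On these data alone, it also remains open whether a larger step would appear with such groups, and whether the two cores would still respond alike.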